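The compounds below may be only part of what the source reports. "The series", "measured", "known", "first", "only" and "open" are said of these compounds alone.

Of the compounds shown here, three built on one shared core have been measured in an ADME assay on microsomes from liver (Homo sapiens) for metabolic stability; on this read-out higher numbers stand for fast clearance and lower numbers for slow clearance. Compound 1, `C[C@H](NC(=O)Cn1nnc2ccccc2c1=O)c1ccc(Cl)cc1`, gives < 9.9 mL/min/kg in this assay, which is a limit of the assay and not a number. Compound 2, `C[C@H](NC(=O)Cn1nnc2ccccc2c1=O)c1ccc(F)cc1`, gives 31 mL/min/kg in this assay. Compound 3, `C[C@H](NC(=O)Cn1nnc2ccccc2c1=O)c1ccc(Br)cc1`, gives < 9.9 mL/min/kg in this assay, again a limit rather than a number. Because two of the three values sit at the limit of < 9.9 mL/min/kg in this assay, at which 2 of the 3 values shown sit, the step that the two limits leave unreadable from compound 1 to compound 3 cannot be read, whereas the step of an at least 3.1-fold higher number from compound 1 to compound 2 (0.49 log units; beyond the scatter) and the step of an at least 3.1-fold lower number from compound 2 to compound 3 (0.49 log units; beyond the scatter) are both readable and point the same way, with fluoro on the aromatic carbon giving the higher number.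

Compound 4, `Cc1ccc([C@H](C)NC(=O)Cn2nnc3ccccc3c2=O)c(F)c1`, differs from compound 1 by 2-fluoro-4-methylphenyl in place of 4-chlorophenyl on a saturated chain carbon bound to an amide-type nitrogen and a saturated chain carbon. The fluoro part of this change has a measured counterpart in the step of an at least 3.1-fold higher number from compound 1 to compound 2 (0.49 log units; beyond the scatter), while the methyl has none among the compounds shown. Compound 4 is therefore expected to move upward, with an estimated step of an at least 3.0-fold higher number from compound 1 to compound 4 (0.48 log units; beyond the scatter). Compound 4 is estimated at 30 mL/min/kg in this assay, with a range from 10 mL/min/kg to 75 mL/min/kg.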

Compound 4, clearance in the Homo sapiens assay: 28 mL/min/kg
Compound 4: middle estimate off by 1.1-fold (0.03 log units), on the high side; the range from low to high includes it.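

In the Homo sapiens assay the change from 4-chlorophenyl to 2-fluoro-4-methylphenyl gives an at least 2.8-fold higher number from compound 1 to compound 4 (0.45 log units; beyond the scatter), and the change from 4-bromophenyl to the same group gives an at least 2.8-fold higher number from compound 3 to compound 4 (0.45 log units; beyond the scatter). Both steps start from a limit of the assay, not a number. In the Homo sapiens assay compound 1 gives < 9.9 mL/min/kg, which is a limit of the assay and not a number. In the Homo sapiens assay compound 3 gives < 9.9 mL/min/kg, which is again a limit of the assay and not a number. In the Homo sapiens assay the change from 4-fluorophenyl gives a 1.1-fold lower number from compound 2 to compound 4 (0.04 log units; within the scatter), so a ring carrying a methyl group, new at this position, reads level with the 4-fluorophenyl ring. The change from 4-chlorophenyl also has a reading in a second assay: in a physicochemical assay for solubility, read by HPLC, in phosphate buffer, with a stated time of 16 h, at pH 6.8 (a lower number here means a less soluble compound, a higher number a more soluble compound), it gives a 2.4-fold higher number from compound 1 to compound 4 (0.37 log units; beyond the scatter). In the physicochemical assay compound 1 gives 1900 nM and compound 4 gives 4500 nM.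

As far as these compounds go, whether the fluoro or the methyl carries these steps stays open, as does how a ring bearing a methoxy group or an amine in place of the methyl would read. The full size of the steps from the limit also stays open: the limit of < 9.9 mL/min/kg in the Homo sapiens assay, at which 2 of the 4 values shown sit.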